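Cytotoxicity of a Thiazolyl Pyrazoline Pair on Fibroblasts

The compounds below may be only part of what the source reports. "The series", "measured", "known", "first", "only" and "open" are said of these compounds alone.

Two compounds from this series were tested in an ADME assay on NIH3T3 cells (Mus musculus) for cytotoxicity, read by XTT assay, with a stated time of 24 h; on this read-out higher numbers stand for weaker inhibition and lower numbers for stronger inhibition. Compound 1 `Fc1ccc(C2CC(c3ccc(Cl)s3)=NN2c2nc(-c3ccc(Cl)cc3)cs2)cc1` sits at a limit of this assay, giving > 500 ug/mL; this is a limit, not a number. Compound 2 `Cc1ccc(C2=NN(c3nc(-c4ccc(Br)cc4)cs3)C(c3ccc(F)cc3)C2)s1` likewise sits at a limit, giving > 500 ug/mL. Both values shown thus lie at the same limit (the limit of > 500 ug/mL in this assay, at which 2 of the 2 values shown sit), so nothing about the order of the two compounds can be read from them.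

Compound 3 `Fc1ccc(C2CC(c3ccc(Cl)s3)=NN2c2nc(-c3ccc(Br)cc3)cs2)cc1` has not yet been measured. It differs from compound 2 by one exchange: chloro in place of methyl on an aromatic carbon. Among the compounds with values here, no measured pair shows the effect of this exchange. Since compound 2 reaches only the limit, the step from compound 2 to compound 3 is expected to be small, a step that the limit leaves unreadable from compound 2 to compound 3, within the scatter or again at the limit. Compound 3 is therefore expected to give about 600 ug/mL, estimated between 300 ug/mL and 1500 ug/mL, most likely reported as a limit once more.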

Compound 3, half-maximal inhibitory concentration: > 500 ug/mL
Compound 3: only a limit was reported; the forecaster's own chance of this, stated with the estimate: 85%; the middle value does not contradict the limit.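

Compound 3 gives > 500 ug/mL, which is a limit and not a number. No step can be read from compound 2 to compound 3 or from compound 1 to compound 3, as all three values sit together: the limit of > 500 ug/mL in this assay, at which 3 of the 3 values shown sit.

The compounds shown leave open whether chloro in place of methyl or bromo in place of chloro changes cytotoxicity at all.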